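Solubility of a shared core with a benzylamine tail

The compounds below may be only part of what the source reports. "The series", "measured", "known", "first", "only" and "open" are said of these compounds alone.

Compound 1 `CC(C)(C)c1ccc(Oc2ccc3c(NCCCNCc4ccco4)ccnc3c2)cc1` carries a tert-butyl group on its distal aryl ring. In a physicochemical assay for solubility, with a stated time of 18 h, at pH 7.4 (on this read-out lower numbers stand for lower solubility and higher numbers for higher solubility), compound 1 gives 14500 nM. Compound 2 `Clc1ccc(Oc2ccc3c(NCCCNCc4ccco4)ccnc3c2)cc1` gives 14500 nM in this assay, and compound 3 `COc1ccc(Oc2ccc3c(NCCCNCc4ccco4)ccnc3c2)cc1` gives 14500 nM. Compound 1 thus stands level with both partners: no change at the digits printed from compound 1 to compound 2 (within the scatter), no change at the digits printed from compound 1 to compound 3 (within the scatter) and no change at the digits printed from compound 2 to compound 3 (within the scatter) all stay within the scatter.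

Compound 4 `COc1cccc(CNCCCNc2ccnc3cc(Oc4ccc(C(C)(C)C)cc4)ccc23)c1O` differs from compound 1 at another place: 2-hydroxy-3-methoxyphenyl in place of furan-2-yl on a saturated chain carbon bound to an amine nitrogen. Within the data shown here, none of the measured steps touches this position; they all exchange the substituent on the distal aryl ring, and each was flat. They show only that the solubility of this series did not move for those three substituents, and they give no direct guide for swapping the furan-2-yl group against a 2-hydroxy-3-methoxyphenyl group on the chain carbon bound to the amine nitrogen.

Among the measured compounds shown here, with no measured precedent for this change, compound 4 is expected to remain close to the common level, at an estimated 12000 nM with a range from 4000 nM to 20000 nM. The expected step of a 1.2-fold lower number from compound 1 to compound 4 (0.08 log units; within the scatter) is therefore estimated to stay within the scatter, though a wider range is allowed than for the measured steps.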

Compound 4, solubility: 14500 nM
The estimate for compound 4 lay 1.2-fold (0.08 log units) below the measured number, and the stated range covers the measured number.
By their numbers in this assay, from the lowest: compounds 1, 2, 3 and 4 (each within the scatter of the next).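

In this assay the chain position now has a measured step of its own, and the result is flat (no change at the digits printed from compound 1 to compound 4 (within the scatter)) for 2-hydroxy-3-methoxyphenyl in place of furan-2-yl on a saturated chain carbon bound to an amine nitrogen. Among these compounds, the earlier steps all changed the substituent on the distal aryl ring, so this is the first reading to show that a five-membered aromatic ring with 1 hetero atom and 0 hydrogen-bond donors can give way to a six-membered aromatic ring of carbon only, with 1 hydrogen-bond donor and 9 heavy atoms in place of 5, with no change beyond the scatter. No measurement offered here accounts for this flat result.

As far as these compounds go, it remains open whether the same exchange would also stay flat with chloro or methoxy on the distal aryl ring in place of tert-butyl. From the compounds shown here alone, all four compounds print the same number, so it is also open whether a dimethylamino group or a carboxylic acid in place of furan-2-yl, or a longer chain at this place, would move the read-out at all.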